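A Fluorine Added to a Pair with Level Inhibition

The compounds below may be only part of what the source reports. "The series", "measured", "known", "first", "only" and "open" are said of these compounds alone.

compound 1, `Cn1cnc2c(Sc3ccc(F)cc3)ncnc21`: 0%
compound 2, `c1ccc(Cn2cnc3c(Sc4ccccc4)ncnc32)cc1`: 1%

In an assay on isolated protein for inhibition of RAC-alpha serine/threonine-protein kinase (Homo sapiens), tested at 30 uM (a higher number here means more inhibition at the concentration tested (going by the name of the read-out), a lower number less inhibition), compound 1 gives 0%, and compound 2 gives 1%; the two numbers lie within the usual scatter of each other, so compound 2 stands level with compound 1, at essentially no inhibition. Compound 3, `Fc1ccc(Sc2ncnc3c2ncn3Cc2ccccc2)cc1`, has not been measured; it differs from compound 2 by one change: fluoro in place of hydrogen on an aromatic carbon. Compound 1 already carries the same fluoro on its six-membered aromatic ring of carbon only, with a different group on the shared core, and shows 0%, so nothing here points to a gain. In this assay the step is expected to be a number 1 percentage points higher from compound 2 to compound 3 (within the scatter), nothing beyond the scatter. Compound 3 is expected to give 2%, within -8% to 12%.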

Compound 3, a percentage reported as inhibition, at one concentration (the size of the read-out at that concentration, not a potency): 1%
For compound 3 the middle estimate is 1 percentage points above the measured one; low and high end bracket the measured number.
By their numbers in this assay, from the lowest: compounds 1, 2 and 3 (each within the scatter of the next).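

In this assay, fluoro in place of hydrogen on an aromatic carbon of the six-membered aromatic ring of carbon only, para to a large group, gives no change at the digits printed from compound 2 to compound 3 (within the scatter). Phenyl in place of hydrogen on a saturated chain carbon bound to an aromatic nitrogen gives a number 1 percentage points higher from compound 1 to compound 3 (within the scatter). Neither change lifts the reading clear of essentially no inhibition, and no supporting measurement bears on this flat result.

Still open, from the compounds shown here alone, is whether an amine or a carboxylic acid on that same ring would produce measurable inhibition.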